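Swapping a basic arm for an acid on the outer ring

A few compounds are considered here, and "the series" means these few. Any claim that something is new, unique, unknown or untested is made for them only; others in the source may bear on it.

Compound 3 `CN(C)Cc1ccc(CNc2ccc(CCC(=O)O)cc2)cc1` carries a (dimethylamino)methyl group on its outer aromatic ring. In a functional assay for agonist activity at Free fatty acid receptor 1 (Homo sapiens) (a higher number here means that more compound is needed for the effect, a lower number that less compound is needed), compound 3 gives only a limit of the assay, < 31700 nM, so no number is known for it. Compound 1 `O=C(O)CCc1ccc(NCc2ccc(C(F)(F)F)cc2)cc1` gives 2000 nM in this assay, and compound 2 `Cc1ccc(CNc2ccc(CCC(=O)O)cc2)cc1` gives 3980 nM. The measured steps give little to lean on: a 2.0-fold higher number from compound 1 to compound 2 (0.30 log units; within the scatter), while a step that the limit leaves unreadable from compound 1 to compound 3 and a step that the limit leaves unreadable from compound 2 to compound 3, a point underlined by the limit of < 31700 nM in this assay, at which 1 of the 3 values shown sits.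

Compound 4 `O=C(O)CCc1ccc(NCc2ccc(C(=O)O)cc2)cc1` differs from compound 3 in one place: carboxy in place of (dimethylamino)methyl on an aromatic carbon. Among the measured compounds shown here, no measured step shows what a carboxy group does at this position, so the expectation rests on the limit of compound 3 alone. Compound 4 is expected to stay in the weak range, with a step that the limit leaves unreadable from compound 3 to compound 4 as the estimated step from the limit. The estimated value for compound 4 in this assay is 15000 nM, within a range from 3000 nM to 60000 nM.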

Compound 4, half-maximal effective concentration: < 31700 nM
Compound 4 ended at the assay's limit; the forecaster's own chance of this, stated with the estimate: 40%; the middle value is on the limit's open side.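

In this assay compound 4 gives < 31700 nM, which is a limit and not a number. No step from compound 1, compound 2 or compound 3 to compound 4 can be read, and the same limit recurs: the limit of < 31700 nM in this assay, at which 2 of the 4 values shown sit.

The compounds shown leave open how carboxy truly compares with methyl or trifluoromethyl at this place.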